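The source may hold more compounds than are shown below. What is called first, only, known or untested is meant among the compounds shown, and "the series" means these compounds.

Among the measured compounds shown here, both compounds measured so far share one core and differ only in the group carried on the saturated chain carbon bound to the ring nitrogen. Compound 1 `Oc1cccc(CNc2nc(-c3ccco3)cc(C(F)(F)F)n2)c1` gives 23000 nM in an assay on HEK-Blue hTLR8 cells for inhibition of Toll-like receptor 8 (Homo sapiens), read by colorimetric assay, with stated times of 1 h and 24 h; a lower number here means a stronger inhibitor, a higher number a weaker inhibitor. Compound 2 `OCc1ccc(CNc2nc(-c3ccco3)cc(C(F)(F)F)n2)cc1` gives 6200 nM in this assay. Compound 1 thus stands at the highest of the two numbers, and its nearest neighbour is compound 2: a 3.7-fold lower number from compound 1 to compound 2 (0.57 log units; beyond the scatter), a modest step.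

Compound 3 `Oc1cccc(CNc2nc(C3CCCCC3)cc(C(F)(F)F)n2)c1` is not yet measured. Its change from compound 1 is cyclohexyl in place of furan-2-yl on an aromatic carbon. For the measured compounds named here, the one step measured so far leaves the furan-2-yl in place and changes the other end of the molecule, so it does not bear on this exchange; no measured pair tells the direction or the size of a change at the aromatic carbon next to the ring nitrogen. With nothing in the data to point either way, the expectation for compound 3 in this assay is a number close to that of compound 1, estimated at 25000 nM with a range from 8000 nM to 80000 nM. This estimate corresponds to a 1.1-fold higher number from compound 1 to compound 3 (0.04 log units; within the scatter), expected to lie within the scatter, with the range left wide to allow a real step in either direction.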

Compound 3, half-maximal inhibitory concentration: 22000 nM
The estimate for compound 3 lay 1.1-fold (0.06 log units) above the measured number; the measured number falls inside the stated range.
By their numbers in this assay, from the lowest: compound 2; then compounds 3 and 1 (each within the scatter of the next).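

In this assay, among the compounds shown here, the exchange of furan-2-yl for cyclohexyl on the aromatic carbon next to the ring nitrogen gives a 1.0-fold lower number from compound 1 to compound 3 (0.02 log units; within the scatter), the first reading at this position. With the 3-hydroxyphenyl end held fixed, a five-membered aromatic ring with 1 hetero atom and a six-membered non-aromatic ring of carbon only therefore read alike, so neither the aromatic character of this group nor the oxygen of furan-2-yl is needed to keep the number at the level of compound 1. No measurement at hand accounts for why the two groups read alike.

This equivalence is shown only against the 3-hydroxyphenyl end, and it remains open whether cyclohexyl would read the same alongside the 4-(hydroxymethyl)phenyl end of compound 2 at 6200 nM in this assay. The tolerance of this carbon is also untested beyond these two rings: a phenyl, a methyl, an amine or a longer alkyl chain there could still move the number in either direction, and the compounds shown give no sign of which way.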